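Shifting One Fluorine: What Compound 3 May Show

The source may report more compounds than this note shows. Statements on the series, on what has been measured and on what is new or still open speak of the compounds shown alone.

Compound 1 (`Nc1n[nH]c2cccc(-c3cccc(NC(=O)Nc4cccc(F)c4)c3)c12`): 1240 nM
Compound 2 (`Nc1n[nH]c2cccc(-c3cccc(NC(=O)Nc4cc(C(F)(F)F)cc(C(F)(F)F)c4)c3)c12`): 3540 nM

Both numbers come from a functional assay on SMMC-7721 cells (Homo sapiens) for inhibition, read by MTT assay, with a stated time of 48 h (a lower number here means a stronger inhibitor, a higher number a weaker inhibitor), and they lie apart by more than the usual scatter. Compound 1 holds the lower of the two numbers, which makes it the stronger inhibitor of this pair. Among the measured compounds shown here, compounds 1 and 2 are the only measured compounds, and they differ by more than a small shift, so neither gives a direct guide to a move of a single fluorine.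

Compound 3 (`Nc1n[nH]c2cccc(-c3cccc(NC(=O)Nc4ccccc4F)c3)c12`) has not yet been measured. It has the same atoms as compound 1, joined differently (2-fluorophenyl in place of 3-fluorophenyl on an amide-type nitrogen): 2-fluorophenyl in place of 3-fluorophenyl on an amide-type nitrogen. For the measured compounds named here, no measured pair shows what this change does, so the expectation stays close to compound 1 (1240 nM) with a wide margin. The step expected is small (a 1.2-fold higher number from compound 1 to compound 3 (0.08 log units; within the scatter)) and is not expected to go beyond the scatter. In this assay compound 3 is estimated at 1500 nM with an expected range of 500 nM to 4500 nM for most repeat measurements.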

Compound 3, half-maximal inhibitory concentration: 2360 nM
Beside the measured number, compound 3's estimate is 1.6-fold (0.20 log units) below it; the range from low to high includes it.
By their numbers in this assay, from the lowest: compounds 1, 3 and 2 (each within the scatter of the next, the first and the last beyond it).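

In this assay, placing 2-fluorophenyl in place of 3-fluorophenyl on an amide-type nitrogen gives a 1.9-fold higher number from compound 1 to compound 3 (0.28 log units; within the scatter) and is the only direct reading of a single change among the compounds shown. Compound 1 and compound 3 have the same atoms, joined differently, so this pair tests the location of the fluorine alone, and in this assay that shift leaves a difference that cannot be told apart from ordinary variation between repeat measurements. No supporting data here explain the size of this step.

The compounds shown leave open what happens at this place when the fluorine gives way to another atom or group on the phenyl ring, such as a chlorine atom, a methoxy group or an amine, or when the ring carries no such group at all. They also leave open whether a fluorine shift of this kind would give a similar reading on other cell lines, where the same pair could behave differently.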